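The compounds below may be only part of what the source reports. "The series", "measured", "known", "first", "only" and "open" are said of these compounds alone.

Of the compounds shown here, three on the shared core have been measured so far. In an assay on HEK293 cells for inhibition of Voltage-dependent T-type calcium channel subunit alpha-1G (Homo sapiens), read by fluorescence, tested at 10 uM (on this read-out higher numbers stand for more inhibition at the one concentration tested (going by the name of the read-out) and lower numbers for less inhibition), compound 1 `CCCc1nc(-c2ccccc2)c(CNCCN2CCN(c3cccc(C(F)(F)F)c3)CC2)o1` gives 56.3%, the highest of the three numbers. Compound 3 `CCCc1nc(-c2ccccc2)c(CNCCCN2CCN(c3ccc(C)cc3)CC2)o1` gives 53.9%, which lies within the scatter of compound 1, while compound 2 `CCCc1nc(-c2ccccc2)c(CNCCCN2CCN(c3ccc(OC)cc3)CC2)o1` gives 42.1%, beyond the scatter and under compound 1. Among the measured compounds shown here, the single measured step, a number 11.8 percentage points higher from compound 2 to compound 3 (beyond the scatter), is the only change at an aromatic carbon in the set. Compound 4 `CCCc1nc(-c2ccccc2)c(CNCCN2CCN(c3cccc(C)c3)CC2)o1` is not yet measured; it differs from compound 1 by methyl in place of trifluoromethyl on an aromatic carbon. For the measured compounds named here, no measured pair sets trifluoromethyl against methyl, and compounds 2 and 3 carry a different chain length from compound 1 and compound 4, so the step from compound 2 to compound 3 bears on the new step only as a sign that a single small group on that ring can shift the number by a modest amount. A modest step in either direction, or none beyond the scatter, is therefore expected. Compound 4 is estimated at 48%, between 30% and 65%. The expected step is a number 8.3 percentage points lower from compound 1 to compound 4 (within the scatter).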

Compound 4, a percentage reported as inhibition, at one concentration (the size of the read-out at that concentration, not a potency): 43.1%
Compound 4: middle estimate off by 4.9 percentage points, on the high side; measured number inside the range.
By their numbers in this assay, from the lowest: compounds 2 and 4 (each within the scatter of the next); then compounds 3 and 1 (each within the scatter of the next).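

In this assay, among the compounds shown here, the change from 3-(trifluoromethyl)phenyl to 3-methylphenyl gives a number 13.2 percentage points lower from compound 1 to compound 4 (beyond the scatter) as the first measured comparison of these two groups. The earlier step at an aromatic carbon, a number 11.8 percentage points higher from compound 2 to compound 3 (beyond the scatter), came from a different pair of groups on a different chain length, so the new step shows that the choice of group at this place, meta to a large group, also moves the number on the chain of compound 1, with trifluoromethyl the higher of the two. Nothing at hand explains the size or direction of this step.

On these data alone, whether a chlorine or a nitrile on the same aromatic carbon would read closer to trifluoromethyl or to methyl remains open. Also open, as far as these compounds go, is whether the same exchange gives a similar step on the chain carried by compound 2 and compound 3.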